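Swapping cyclohexyl for sec-butyl on the amine nitrogen

A few compounds are considered here, and "the series" means these few. Any claim that something is new, unique, unknown or untested is made for them only; others in the source may bear on it.

Compound 1 `COc1cc(/C=C/C(=O)/C=C(/C=C/c2ccc(OC(C)=O)c(OC)c2)NC2CCCCC2)ccc1OC(C)=O`: 62%
Compound 2 `COc1cc(/C=C/C(=O)CC(=O)/C=C/c2ccc(OC(C)=O)c(OC)c2)ccc1OC(C)=O`: 90%
Compound 3 `CCC(C)NC(=C\C(=O)/C=C/c1ccc(O)cc1)/C=C/c1ccc(O)cc1`: 102%

Of the compounds shown here, three have been measured in a functional assay on Caco-2 cells (Homo sapiens), read by fluorescence, tested at 10 uM; a higher number here means a weaker effect of the compound at the concentration tested, a lower number a stronger effect. Compound 1 gives 62%, the lowest of the three numbers and therefore the strongest effect in this set. Its nearest neighbour is compound 2, which gives 90%, a number beyond the scatter higher than that of compound 1. Compound 3 gives 102%, the furthest from compound 1 and also beyond the scatter. Compound 3 carries the (sec-butyl)amino group on the core but bears free hydroxyls on its aryl rings, so its distance from compound 1 cannot be read as the effect of the amine substituent alone.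

The unmeasured compound 4 `CCC(C)NC(=C\C(=O)/C=C/c1ccc(OC(C)=O)c(OC)c1)/C=C/c1ccc(OC(C)=O)c(OC)c1` keeps the aryl groups of compound 1 and changes only the amine substituent: sec-butyl in place of cyclohexyl on an amine nitrogen. For the measured compounds named here, no measured pair shows this change on its own. A small step in this assay is expected, towards a weaker effect, and it may well lie within the scatter. Compound 4 is therefore estimated at 72%, in the range 50% to 95%, an expected step of a number 10 percentage points higher from compound 1 to compound 4 (within the scatter).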

Compound 4, a percentage reported as activity, at one concentration (the size of the read-out at that concentration, not a potency): 86%
Beside the measured number, compound 4's estimate is 14 percentage points below it, and the stated range covers the measured number.
By their numbers in this assay, from the lowest: compound 1; then compounds 4 and 2 (each within the scatter of the next); then compound 3.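

For the compounds shown here, compound 1 and compound 4 form the first pair in this set that differs in one place only, and with the aryl groups unchanged, sec-butyl in place of cyclohexyl on an amine nitrogen shifts the read-out in this assay by a number 24 percentage points higher from compound 1 to compound 4 (beyond the scatter). Going by these compounds alone, the amine substituent alone therefore matters at this position, and this change goes towards a weaker effect, which the earlier compounds could not separate from their other differences. No measurement at hand bears on why the step occurs.

The compounds shown leave open whether the ring itself counts at this nitrogen or only the size of the substituent: a cyclopentyl group and an open n-hexyl chain in the same place would begin to separate the two. They also leave open whether the step carries over to the free hydroxyl form of the aryl rings seen in compound 3, which a cyclohexylamino group on that same scaffold would test directly.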